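The source may report more compounds than this note shows. Statements on the series, on what has been measured and on what is new or still open speak of the compounds shown alone.

Of the compounds shown here, three have been measured in a functional assay on RKO cells (Homo sapiens) for inhibition, read by MTT assay, with a stated time of 48 h; on this read-out lower numbers stand for stronger inhibition and higher numbers for weaker inhibition. Compound 1, `Cc1nc(N(C)c2ccc([Se]C#N)c(Cl)c2)c2ccccc2n1`, gives 11 nM and stands as the most potent of the three, since its gaps to both other compounds lie beyond the usual scatter. Compound 2, `COc1ccc(N(C)c2nc(C)nc3ccccc23)cc1C(=O)OCCCCC[Se]C#N`, gives 356 nM, and compound 3, `COc1ccc(N(C)c2nc(C)nc3ccccc23)cc1OCCCCC[Se]C#N`, gives 3560 nM. Among these three there is no pair that differs in a single place, so no measured step of that kind is available for comparison.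

Compound 4, `Cc1nc(N(C)c2ccc([Se]C#N)c(F)c2)c2ccccc2n1`, has not yet been measured. Relative to compound 1 it differs as follows: fluoro in place of chloro on an aromatic carbon. Going by the values given here, no measured pair shows what this exchange of one halogen for another does in this assay. An exchange of this kind is expected to move the half-maximal inhibitory concentration only modestly, most likely toward a somewhat higher number, with a fair chance of no step beyond the scatter. Compound 4 is therefore estimated at 20 nM, within a range from 6 nM to 70 nM. This corresponds to an expected step of a 1.8-fold higher number from compound 1 to compound 4 (0.26 log units; within the scatter).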

Compound 4, half-maximal inhibitory concentration: 8 nM
Compound 4: the middle estimate sits 2.5-fold (0.40 log units) above what was measured, within the range that was stated.
By their numbers in this assay, from the lowest: compounds 4 and 1 (each within the scatter of the next); then compound 2; then compound 3.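

In this assay, the exchange of chloro for fluoro on this aromatic carbon, ortho to a group of 3 heavy atoms, gives a 1.4-fold lower number from compound 1 to compound 4 (0.14 log units; within the scatter). Going by these compounds alone, this is the first single-place comparison, and it shows that the low number of compound 1 does not depend on chloro in particular, since fluoro at the same place leaves a result that cannot be told apart from it. No measurement is at hand that would account for this equivalence of the two halogens.

The compounds shown leave open whether this position accepts only halogens, since nothing shows what bromo, a methoxy group or an amine would do there. They also leave open what a bare aromatic carbon hydrogen at this place would give, so the contribution of either halogen cannot yet be read.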